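Phenyl for ethyl on the ring nitrogen of compound 1

The source may report more compounds than this note shows. Statements on the series, on what has been measured and on what is new or still open speak of the compounds shown alone.

Three compounds have been measured in a functional assay on DU-145 cells (Homo sapiens) for cytotoxicity, read by sulforhodamine B assay, with a stated time of 48 h; a lower number here means a stronger inhibitor of growth, a higher number a weaker inhibitor of growth:

compound 1 `CCN1CCN(c2nc(Nc3ccc(C#N)c(C(F)(F)F)c3)nc(Oc3ccnc4ccccc34)n2)CC1` gives 86600 nM
compound 2 `COc1ccc(CN2CCN(c3nc(Nc4ccc(C#N)c(C(F)(F)F)c4)nc(Oc4ccnc5ccccc45)n3)CC2)c(OC)c1OC` gives > 100000 nM, a limit of the assay
compound 3 `N#Cc1ccc(Nc2nc(Oc3ccnc4ccccc34)nc(N3CCN(C(c4ccccc4)c4ccccc4)CC3)n2)cc1C(F)(F)F` gives > 100000 nM, a limit of the assay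

Compound 1 is thus the only one of the three with a number in this assay; the other two sit at the limit of > 100000 nM in this assay, at which 2 of the 3 values shown sit. Compound 4 `N#Cc1ccc(Nc2nc(Oc3ccnc4ccccc34)nc(N3CCN(c4ccccc4)CC3)n2)cc1C(F)(F)F` differs from compound 1 by phenyl in place of ethyl on an amine nitrogen in a ring, that is, 4-ethylpiperazin-1-yl becomes 4-phenylpiperazin-1-yl. Among the measured compounds shown here, one measured step bears on this: an at least 1.1-fold higher number from compound 1 to compound 2 (0.06 log units; that floor lies within the scatter), where the bulkier group on that ring leads to a value at the limit. Compound 3, carrying a benzhydryl group on the same nitrogen, also sits at the limit. Both point the same way for compound 4: a number expected to rise from compound 1, most likely beyond what this assay can report, by about a 1.7-fold higher number from compound 1 to compound 4 (0.24 log units; within the scatter). Compound 4 is therefore estimated at 150000 nM, with a range from 60000 nM to 400000 nM.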

Compound 4, concentration for 50% growth inhibition: > 100000 nM
Compound 4: only a limit was reported (the forecaster's own chance of this, stated with the estimate: 70%); the middle value lies beyond the limit too.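

In this assay, phenyl in place of ethyl on the ring nitrogen gives an at least 1.1-fold higher number from compound 1 to compound 4 (0.06 log units; that floor lies within the scatter), so only a floor for this step can be read, and that floor does not separate the two compounds. Compound 4 gives > 100000 nM, which is a limit of the assay and not a number. Compound 2 and compound 3 carry a saturated carbon on this nitrogen, whereas compound 4 has an aromatic ring bound to it directly, and this form also ends at the limit, leaving compound 1 the only one with a number: the limit of > 100000 nM in this assay, at which 3 of the 4 values shown sit.

The compounds shown leave open whether a hydrogen, a methyl or a hydroxyethyl chain on this nitrogen would give a lower number than ethyl does. As far as these compounds go, compound 2, compound 3 and compound 4 have no numbers, so their order among themselves also stays open.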